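A Trifluoromethyl Swap at the Limit of Cytotoxicity

The source may hold more compounds than are shown below. What is called first, only, known or untested is meant among the compounds shown, and "the series" means these compounds.

In an ADME assay on BJ cells (Homo sapiens) for cytotoxicity, read by CellTiter-Glo and resazurin assay, with a stated time of 72 h (a lower number here means that less compound is needed, a higher number that more compound is needed for the effect), compound 3 `CCOC(=O)CCCCCOc1cccc(CN(C(=O)c2ccc(-c3cc(OC)cc(OC)c3)cc2)C(C)C)c1` gives only a limit, > 26000 nM. Compound 1 `CCOC(=O)CCCCCOc1cccc(CN(C(=O)c2ccc(-c3cccc(N(C)C)c3)cc2)C(C)C)c1` also gives only a limit, > 26000 nM. Compound 2 `CCOC(=O)CCCCCOc1cccc(CN(C(=O)c2ccc(-c3cccc(OCC)c3)cc2)C(C)C)c1` likewise gives a limit, > 22300 nM.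

Compound 4 `CCOC(=O)CCCCCOc1cccc(CN(C(=O)c2ccc(-c3cccc(C(F)(F)F)c3)cc2)C(C)C)c1` has 3-(trifluoromethyl)phenyl in place of 3,5-dimethoxyphenyl on an aromatic carbon. Two measured changes at this same aryl group bear on it: a step that the two limits leave unreadable from compound 1 to compound 3, and a step that the two limits leave unreadable from compound 2 to compound 3. Neither gives a size to carry over, so the expectation rests only on all three compounds ending at limits. The expected change is a step that the limit leaves unreadable from compound 3 to compound 4, with no shift beyond the scatter anticipated. For compound 4 the estimated value is 28000 nM, with an expected range from 12000 nM to 50000 nM.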

Compound 4, half-maximal effective concentration: < 1.3 nM
Compound 4 was reported as a limit; the forecaster's own chance of this, stated with the estimate: 85%; at least 21000-fold (4.33 log units) between middle value and limit.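

In this assay, within the data shown here, this aryl position proves able to move the number sharply, which the earlier compounds could not show because their steps among one another cannot be read. Trifluoromethyl gives an at least 20000-fold lower number from compound 3 to compound 4 (4.30 log units; beyond the scatter), an at least 17000-fold lower number from compound 2 to compound 4 (4.23 log units; beyond the scatter) and an at least 20000-fold lower number from compound 1 to compound 4 (4.30 log units; beyond the scatter). Compound 4 is reported only as a limit: the limit of < 1.3 nM in this assay, at which 1 of the 4 values shown sits.

The compounds shown leave open whether a nitrile or a chlorine at the same place would give a similar step. Also open, on these data alone, is what a carboxylic acid in place of the ethyl ester would do to compound 4.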